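This account rests on a few compounds, and the source may have more. Where it says the series, first, only, none or still open, it means among the compounds named here.

Measured so far in a functional assay on U-251 cells (Homo sapiens) for inhibition, read by sulforhodamine B assay, with a stated time of 48 h; a lower number here means a stronger inhibitor of growth, a higher number a weaker inhibitor of growth:

Compound 1 `COc1ccc(/C=C/C2CC(=O)C=CO2)cc1` gives 152 uM.
Compound 2 `COc1ccc(/C=C/C2CC(=O)C=CO2)cc1OC` gives 86.9 uM.
Compound 3 `COc1ccc(/C=C/C2CC=CC(=O)O2)cc1` gives 20.6 uM.

Compound 2 differs from compound 1 by methoxy in place of hydrogen on an aromatic carbon, and the resulting step in this assay is a 1.7-fold lower number from compound 1 to compound 2 (0.24 log units; within the scatter). Compound 3 is built on a different core from compound 1; the two have the same atoms joined differently, and the difference between the two cores is not broken down here. Compound 3 stands at the lowest number of the three, beyond the scatter from both compound 1 and compound 2.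

Compound 4 `COc1ccc(/C=C/C2CC=CC(=O)O2)cc1OC` is not yet measured. It differs from compound 3 by methoxy in place of hydrogen on an aromatic carbon, the same change that took compound 1 to compound 2, at a place described in the same words. On that basis the step from compound 3 to compound 4 in this assay is expected to be small, about a 1.5-fold lower number from compound 3 to compound 4 (0.17 log units; within the scatter), resting on the step of a 1.7-fold lower number from compound 1 to compound 2 (0.24 log units; within the scatter) seen on the other core. For compound 4 the estimated value in this assay is 14 uM, with a likely range from 6 uM to 35 uM.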

Compound 4, concentration for growth inhibition (reported as GI): 23.9 uM
Beside the measured number, compound 4's estimate is 1.7-fold (0.23 log units) below it; the range from low to high includes it.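

In this assay the step for methoxy in place of hydrogen on an aromatic carbon is a 1.2-fold higher number from compound 3 to compound 4 (0.06 log units; within the scatter) and matches the small step seen on the core of compound 1. This supports carrying this one change, at this one place, between these two cores, but it rests on a single pair per core and does not show that other changes would carry across in the same way. The two steps do not differ: the same change on two cores in this assay, a 1.7-fold lower number (0.24 log units; within the scatter) from compound 1 to compound 2 and a 1.2-fold higher number (0.06 log units; within the scatter) from compound 3 to compound 4, 2.0-fold (0.31 log units) apart, within the scatter of two such steps

Still open, going by these compounds, is how other groups on the aromatic ring, such as an amine, a carboxylic acid or a longer chain, would behave on each core. Also open, on these data alone, is whether a step beyond the scatter would carry from one core to the other.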